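Dichlorophenyl Variant of a Phenylbutanamide Oxidase Inhibitor

This account rests on a few compounds, and the source may have more. Where it says the series, first, only, none or still open, it means among the compounds named here.

In an assay on mitochondria (strain Sprague-Dawley) for inhibition of Amine oxidase [flavin-containing] B (Rattus norvegicus), read by fluorescence and Amplex Red, with stated times of 30 min and 45 min (on this read-out higher numbers stand for weaker inhibition and lower numbers for stronger inhibition), compound 1 `O=C(CCc1ccccc1)Nc1nc2ccccc2c(=O)s1` gives 42.7 nM, compound 2 `COc1cccc(CCC(=O)Nc2nc3ccccc3c(=O)s2)c1` gives 621 nM, and compound 3 `O=C(CCCc1ccccc1)Nc1nc2ccccc2c(=O)s1` gives 186 nM, the second highest of the three numbers, with the step of a 4.4-fold higher number from compound 1 to compound 3 (0.64 log units; beyond the scatter) separating it from the lowest. Compound 4 `O=C(CCCc1ccc(Cl)c(Cl)c1)Nc1nc2ccccc2c(=O)s1` differs from compound 3 by 3,4-dichlorophenyl in place of phenyl on a saturated chain carbon, three bonds along the chain from a carbonyl carbon. For the measured compounds named here, the only measured step that alters the aromatic ring is a 15-fold higher number from compound 1 to compound 2 (1.16 log units; beyond the scatter), a large loss; the step of a 3.3-fold lower number from compound 2 to compound 3 (0.52 log units; beyond the scatter) changes ring substitution and chain together. With one ring-substitution precedent pointing to weaker inhibition, a step of a 2.4-fold higher number from compound 3 to compound 4 (0.38 log units; beyond the scatter) is expected for compound 4, a loss beyond the scatter but smaller than the methoxy case. The estimated value for compound 4 in this assay is 450 nM, with a range from 120 nM to 1700 nM.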

Compound 4, half-maximal inhibitory concentration: 3300 nM
The estimate for compound 4 lay 7.3-fold (0.87 log units) below the measured number; the whole stated range lies below it.
By their numbers in this assay, from the lowest: compound 1; then compound 3; then compound 2; then compound 4.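

The change to 3,4-dichlorophenyl on this chain is not a mild one: it gives an 18-fold higher number from compound 3 to compound 4 (1.25 log units; beyond the scatter), a loss as large in class as a 15-fold higher number from compound 1 to compound 2 (1.16 log units; beyond the scatter). Both compounds shown with a single change to the aromatic ring therefore lose inhibition, one on each chain length, so this loss is not confined to methoxy or to the shorter chain. Nothing available here explains the size of this loss.

The compounds shown leave open whether it takes both chlorines or one alone. They also leave open how a fluorine or a hydroxyl on this ring would compare with compound 3.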